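The source may report more compounds than this note shows. Statements on the series, on what has been measured and on what is new or still open speak of the compounds shown alone.

Measured so far:
compound 1, `COc1ccc(-n2cc(-c3ccccc3)c(-c3ccc4c(c3)NC(=O)CO4)n2)cc1`: 35.6%
compound 2, `O=C1COc2ccc(-c3nn(-c4ccc(Cl)cc4)cc3-c3ccccc3)cc2N1`: 47.1%

Both compounds were tested in a functional assay on DLD-1 cells (Homo sapiens) for cytotoxicity, read by colorimetric assay and MTT assay, with a stated time of 3 days, tested at 20 uM; a higher number here means a weaker effect of the compound at the concentration tested, a lower number a stronger effect. In this assay compound 1 gives 35.6%, and compound 2 gives 47.1%. Among the compounds with values here, compound 2 thus has the higher of the two numbers; the single measured step, a number 11.5 percentage points higher from compound 1 to compound 2 (beyond the scatter), is modest.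

Compound 3, `O=C1COc2ccc(-c3nn(-c4cc(Cl)cc(Cl)c4)cc3-c3ccccc3)cc2N1`, is not yet measured. It differs from compound 2 in one place: 3,5-dichlorophenyl in place of 4-chlorophenyl on an aromatic nitrogen. Within the data shown here, no measured step shows what adding a second chlorine to this ring does, and the only step available, a number 11.5 percentage points higher from compound 1 to compound 2 (beyond the scatter), concerns a different exchange on that ring, so it bears on this question only loosely. The expectation is therefore a step of a number 2.9 percentage points higher from compound 2 to compound 3 (within the scatter) in this assay for compound 3, that is, no clear change beyond the scatter. On this basis compound 3 is estimated at 50%, with a range from 30% to 75%.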

Compound 3, a percentage reported as activity, at one concentration (the size of the read-out at that concentration, not a potency): 52.2%
For compound 3 the middle estimate is 2.2 percentage points below the measured one; low and high end bracket the measured number.
By their numbers in this assay, from the lowest: compound 1; then compounds 2 and 3 (each within the scatter of the next).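

In this assay, the exchange of 4-chlorophenyl for 3,5-dichlorophenyl on the aromatic nitrogen gives a number 5.1 percentage points higher from compound 2 to compound 3 (within the scatter), so at this position the second chlorine brings no clear change. Set against the 4-methoxyphenyl group of compound 1, the 3,5-dichlorophenyl group gives a number 16.6 percentage points higher from compound 1 to compound 3 (beyond the scatter); the effect on the cells is weaker at the tested concentration, as it also is with 4-chlorophenyl in compound 2. Nothing available here explains these numbers.

The compounds shown leave open how the ring on this nitrogen would behave if it carried an amine or a carboxylic acid instead of chlorine or methoxy. They also leave open whether replacing the phenyl group on the five-membered ring with a longer chain would shift the read-out.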